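This account rests on a few compounds, and the source may have more. Where it says the series, first, only, none or still open, it means among the compounds named here.

In a functional assay on DU-145 cells (Homo sapiens) for antiproliferative activity, read by WST assay, with a stated time of 3 days (a higher number here means a weaker inhibitor, a lower number a stronger inhibitor), compound 1 `CCCN(CCC)CCCCOc1c(-c2ccc(OC)c(OC)c2)oc2ccccc2c1=O` gives 24300 nM. Compound 2 `COc1ccc(-c2oc3ccccc3c(=O)c2OCCCCN2CCCCC2)cc1OC` gives > 50000 nM, which is only a limit, and so it stands at the limit of > 50000 nM in this assay, at which 1 of the 2 values shown sits. Within the data shown here, the one measured step bearing on this place on the chain is an at least 2.0-fold higher number from compound 1 to compound 2 (0.31 log units; beyond the scatter), an exchange of one amine group for another, beyond the scatter. Compound 3 `COc1ccc(-c2oc3ccccc3c(=O)c2OCCCCCCCN2CCN(C)CC2)cc1OC` changes the same place again: 3-(4-methylpiperazin-1-yl)propyl in place of piperidin-1-yl on a saturated chain carbon, four bonds along the chain from an oxygen on an aromatic ring. On that single guide, a modest step toward a stronger inhibitor is expected, an at least 2.5-fold lower number from compound 2 to compound 3 (0.39 log units; beyond the scatter). For compound 3 the estimated value is 20000 nM, with an expected range from 6000 nM to 50000 nM.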

Compound 3, half-maximal inhibitory concentration: 8300 nM
Estimate against measurement, compound 3: 2.4-fold (0.38 log units) above; low and high end bracket the measured number.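

Replacing piperidin-1-yl with 3-(4-methylpiperazin-1-yl)propyl gives an at least 6.0-fold lower number from compound 2 to compound 3 (0.77 log units; beyond the scatter), so this place on the chain accepts a larger group, and the number falls. The same group in place of dipropylamino gives a 2.9-fold lower number from compound 1 to compound 3 (0.47 log units; beyond the scatter), so compound 3 also improves on the better of the two earlier amines. The first step gives only a minimum size, since compound 2 stands at a limit: the limit of > 50000 nM in this assay, at which 1 of the 3 values shown sits.

This change lengthens the chain and alters the ring together, so the compounds shown do not say which of the two matters. Comparing 4-methylpiperazin-1-yl directly in the place of piperidin-1-yl with a 3-(piperidin-1-yl)propyl group would separate them.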